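The compounds below may be only part of what the source reports. "The series", "measured", "known", "first", "only" and "open" are said of these compounds alone.

Of the compounds shown here, three that share one core have so far been measured in a physicochemical assay for solubility, at pH 7.4; a higher number here means a more soluble compound, a lower number a less soluble compound. Compound 1, `C[C@H]1[C@H](N)CN1c1c(F)cc2c(=O)c(C(=O)O)cn(C3CC3)c2c1Cl`, gives 12 ug/mL in this assay. Compound 2, `C[C@H]1[C@@H](N)CN1c1c(F)cc2c(=O)c(C(=O)O)cn(C3CC3)c2c1F`, gives 23.6 ug/mL, and compound 3, `C[C@H]1[C@H](N)CN1c1c(F)c(N)c2c(=O)c(C(=O)O)cn(C3CC3)c2c1F`, gives 37.7 ug/mL. Compound 1 thus stands at the lowest of the three numbers. Going by the values given here, its gap to compound 2 lies within the scatter of repeated measurements, so the two cannot be placed in order; its gap to compound 3 lies beyond the scatter, so compound 3 is the one compound here that is clearly more soluble than compound 1.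

Compound 4, `C[C@H]1[C@H](N)CN1c1cc2c(cc1F)c(=O)c(C(=O)O)cn2C1CC1`, has not yet been measured in this assay. It differs from compound 1 in a single place: hydrogen in place of chloro on an aromatic carbon. Among the compounds with values here, no measured pair shows this exact change, so the data give no direct reading of how large a step it brings. Compound 3 carries a different change on the same core and stands beyond the scatter above compound 1, while compound 2 stands within the scatter of it; a small rise for compound 4 seems the likelier outcome, without any measured step to anchor it. The estimate for compound 4 is 28 ug/mL, with a range from 10 ug/mL to 80 ug/mL. That estimate would mean an expected step of a 2.3-fold higher number from compound 1 to compound 4 (0.37 log units; beyond the scatter).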

Compound 4, solubility: 9.9 ug/mL
Compound 4: the middle estimate sits 2.8-fold (0.45 log units) above what was measured; the measured number lies below the stated range.
By their numbers in this assay, from the lowest: compounds 4, 1, 2 and 3 (each within the scatter of the next, the first and the last beyond it).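

In this assay, going by these compounds alone, hydrogen in place of chloro on this aromatic carbon gives a 1.2-fold lower number from compound 1 to compound 4 (0.08 log units; within the scatter), the first measured reading of this change, and compounds 1 and 4 cannot be placed in order. For this one pair, then, having chloro or hydrogen at this place, ortho to a fused ring and meta to a fluoro group, makes no difference that the measurement can resolve. Nothing available explains this result, so the data cannot say why the step stays within the scatter.

Still open, on these data alone, is whether a different group on this same carbon, such as a methoxy group or a nitrile, would give a step beyond the scatter from compound 1. Compound 2 and compound 3 each differ from compound 4 in more than one place, so neither can show whether this change would give an equally small step in a compound that also differs elsewhere on the shared core.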